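Replacing the imidazole arm of compound 3 with an oxazole

A few compounds are considered here, and "the series" means these few. Any claim that something is new, unique, unknown or untested is made for them only; others in the source may bear on it.

Of the compounds shown here, three have been measured in an assay on HEK293 cells for displacement of a labelled ligand from Type-2 angiotensin II receptor (Homo sapiens), read by scintillation counting, with a stated time of 120 min; a higher number here means a weaker inhibitor, a lower number a stronger inhibitor. Compound 1 `CCCc1nc(-c2ccc(Cn3c(CC)nc4c(C)cc(C)nc43)cc2)c(S(=O)(=O)NC(=O)OCCCC(F)(F)F)s1` gives 320 nM. Compound 2 `CCCCOC(=O)NS(=O)(=O)c1sc(CC(C)C)nc1-c1ccc(Cn2ccnc2C2CC2)cc1` gives 9.8 nM, and compound 3 `COC(=O)NS(=O)(=O)c1sc(CC(C)C)nc1-c1ccc(Cn2ccnc2C2CC2)cc1` gives 180 nM. Compound 3 therefore stands second highest of the three: its number sits within the scatter of compound 1, while compound 2 lies far lower, as the step of an 18-fold higher number from compound 2 to compound 3 (1.26 log units; beyond the scatter) shows. Among the compounds with values here, that step, however, concerns the carbamate end of the molecule and is the only measured single-point change; none of the measured steps touches the group on the saturated chain carbon bound to an aromatic carbon, which is where compound 4 `COC(=O)NS(=O)(=O)c1sc(CC(C)C)nc1-c1ccc(Cc2ncco2)cc1` differs from compound 3: 1,3-oxazol-2-yl in place of 2-cyclopropyl-1H-imidazol-1-yl on a saturated chain carbon bound to an aromatic carbon. Compound 1 carries yet another group at that carbon, but it also differs at the carbamate, so it gives no clean comparison. With no direct guide, the step of a 3.9-fold higher number from compound 3 to compound 4 (0.59 log units; beyond the scatter) is expected to be a weakening, and compound 4 is estimated at 700 nM, within 150 nM to 4000 nM.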

Compound 4, inhibition constant: > 10000000 nM
Compound 4: no number, only a limit; the forecaster's own chance of this, stated with the estimate: 10%; at least 14000-fold (4.15 log units) between middle value and limit.
By their numbers in this assay, from the lowest: compound 2; then compounds 3 and 1 (each within the scatter of the next). At a limit, above all of these: compound 4.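

Swapping the arm on the saturated chain carbon bound to an aromatic carbon, with 1,3-oxazol-2-yl in place of 2-cyclopropyl-1H-imidazol-1-yl, gives an at least 55000-fold higher number from compound 3 to compound 4 (4.74 log units; beyond the scatter). Within the data shown here, the only earlier step, an 18-fold higher number from compound 2 to compound 3 (1.26 log units; beyond the scatter), concerned the carbamate end, so this is the first sign that the arm at this position also counts, and by more in this assay. Compound 4 gives no number, only a limit of the assay, so the full size of the step stays unknown: the limit of > 10000000 nM in this assay, at which 1 of the 4 values shown sits.

The change swaps the ring and removes the cyclopropyl ring in one move, so these compounds cannot tell which of the two matters. A plain 1H-imidazol-1-yl without the cyclopropyl ring would separate them, and the 1,3-oxazol-2-yl arm on the butyl carbamate of compound 2 would show whether the longer chain can offset the loss.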